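This account rests on a few compounds, and the source may have more. Where it says the series, first, only, none or still open, it means among the compounds named here.

Measured so far:
compound 1 `Oc1ccc(-c2cc(-c3ccccc3O)cc(-c3cccc(O)c3)n2)cc1` — 650 nM
compound 2 `Oc1ccc(-c2cc(-c3cccc(O)c3)nc(-c3cccc(O)c3)c2)cc1` — 2230 nM

In a functional assay on T47D cells (Homo sapiens) for cytotoxicity, read by CCK-8 assay, with a stated time of 4 days (a higher number here means a weaker inhibitor, a lower number a stronger inhibitor), compound 1 gives 650 nM, and compound 2 gives 2230 nM. Compound 2 therefore stands at the higher of the two numbers in this assay, its nearest neighbour being compound 1, which lies beyond the scatter from it. The two compounds differ in more than one place, so their values are compared only as they stand.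

The next compound is compound 3 `Oc1cccc(-c2cc(-c3ccccc3O)cc(-c3cccc(O)c3)n2)c1`, which is obtained from compound 2 by one change: 2-hydroxyphenyl in place of 4-hydroxyphenyl on an aromatic carbon. For the measured compounds named here, no measured step isolates this change. Going by the values given here, compound 1, the only measured compound that also carries a 2-hydroxyphenyl group, gives 650 nM, the lower of the two numbers, which is the sole guide available. On that basis the step from compound 2 to compound 3 is expected to run towards a lower number, a 2.2-fold lower number from compound 2 to compound 3 (0.35 log units; beyond the scatter), at the edge of the scatter rather than clearly beyond it. Compound 3 is accordingly estimated at 1000 nM, within a range of 400 nM to 2500 nM.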

Compound 3, half-maximal inhibitory concentration: 4570 nM
Beside the measured number, compound 3's estimate is 4.6-fold (0.66 log units) below it; measured number above the stated range.
By their numbers in this assay, from the lowest: compound 1; then compound 2; then compound 3.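

In this assay, the position opposite the ring nitrogen, with two 3-hydroxyphenyl groups on the core, tolerates 2-hydroxyphenyl less well than 4-hydroxyphenyl, with a 2.0-fold higher number from compound 2 to compound 3 (0.31 log units; beyond the scatter) for a change that only moves the hydroxyl around the ring. A 2-hydroxyphenyl group alone therefore does not bring a low number, since compound 3 carries one and still has the highest number of the three. Its effect depends on the other aryl groups: with the 2-hydroxyphenyl group kept, the other change gives a 7.0-fold higher number from compound 1 to compound 3 (0.85 log units; beyond the scatter), the larger of the two steps.

Nothing available explains either step. Open, on these data alone, is how a 3-hydroxyphenyl group at the position opposite the ring nitrogen would compare, and whether an aminophenyl or methoxyphenyl group there would follow the same order.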